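The source may hold more compounds than are shown below. What is called first, only, known or untested is meant among the compounds shown, and "the series" means these compounds.

Measured compounds in a functional assay on the whole organism with Rattus norvegicus as the target; a higher number here means that more compound is needed for the effect, a lower number that less compound is needed:
compound 1 `CCOC(=O)C(=O)Nc1cccc(N(C)C)c1C#N`: 4.2 mg/kg
compound 2 `CCCNc1cccc(NC(=O)C(=O)OCC)c1C#N`: 0.7 mg/kg
compound 3 `CCOC(=O)C(=O)Nc1cccc(C)c1C#N`: 4.6 mg/kg

Compound 1 stands second highest of the three numbers. Its nearest neighbour is compound 3, with a 1.1-fold higher number from compound 1 to compound 3 (0.04 log units; within the scatter), a step within the scatter, so no order between compound 1 and compound 3 can be drawn. The furthest is compound 2, with a 6.0-fold lower number from compound 1 to compound 2 (0.78 log units; beyond the scatter); the step of a 6.6-fold higher number from compound 2 to compound 3 (0.82 log units; beyond the scatter) is of the same size in the opposite sense.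

Compound 4 `CCOC(=O)C(=O)Nc1cccc([N+](=O)[O-])c1C#N` has not yet been measured in this assay. It differs from compound 1 by nitro in place of dimethylamino on an aromatic carbon. Going by the values given here, no measured step exchanges dimethylamino for nitro, so the known steps bear on it only indirectly. The step of a 1.1-fold higher number from compound 1 to compound 3 (0.04 log units; within the scatter) shows that replacing the dimethylamino with methyl leaves the number where it was, while a 6.0-fold lower number from compound 1 to compound 2 (0.78 log units; beyond the scatter) shows that only the propylamino among the measured groups moves it. With nothing in the series pointing either way for nitro, the expectation for compound 4 is no step beyond the scatter, a 1.2-fold higher number from compound 1 to compound 4 (0.08 log units; within the scatter), with wide uncertainty. Compound 4 is therefore estimated at 5 mg/kg, with a range from 1.5 mg/kg to 15 mg/kg.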

Compound 4, dose for half-maximal effect: 82 mg/kg
For compound 4 the middle estimate is 16-fold (1.21 log units) below the measured one, and the stated range ends below it.
By their numbers in this assay, from the lowest: compound 2; then compounds 1 and 3 (each within the scatter of the next); then compound 4.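

In this assay, going by these compounds alone, the position ortho to a cyano group proves able to move the number upward as well as downward: nitro gives a 20-fold higher number from compound 1 to compound 4 (1.29 log units; beyond the scatter) when it replaces dimethylamino and an 18-fold higher number from compound 3 to compound 4 (1.25 log units; beyond the scatter) when it replaces methyl, whereas the earlier compounds showed only the downward move with propylamino. Dimethylamino and nitro have the same heavy-atom count, so that count does not separate them, and the two ends of the series now lie far apart, with a 120-fold higher number from compound 2 to compound 4 (2.07 log units; beyond the scatter) when nitro replaces propylamino. Nothing available on these compounds speaks to the origin of the nitro result.

Each group at this position is represented by a single compound, so neither propylamino at the low end nor nitro at the high end can yet be read as part of a trend. Open too, from the compounds shown here alone, is whether an unsubstituted amino group or a longer chain such as butylamino would stay with propylamino, and whether trifluoromethyl or a carboxylic acid would stay with nitro.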